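This account rests on a few compounds, and the source may have more. Where it says the series, first, only, none or still open, it means among the compounds named here.

Three compounds sharing one core have been run in a functional assay on HOS cells (Homo sapiens) for antiproliferative activity, with a stated time of 72 h; a lower number here means a stronger inhibitor, a higher number a weaker inhibitor. Compound 1 `OC[C@H]1O[C@@H](n2cnc3c(NCc4ccc(Cl)cc4)ncnc32)[C@H](O)[C@@H]1O` returns in this assay only a limit, > 166000 nM. Compound 2 `Cc1ccc(CNc2ncnc3c2ncn3[C@@H]2O[C@H](CO)[C@@H](O)[C@H]2O)cc1` likewise gives only a limit in this assay, > 166000 nM. Compound 3 `COc1cccc(CNc2ncnc3c2ncn3[C@@H]2O[C@H](CO)[C@@H](O)[C@H]2O)c1` also reaches only a limit in this assay, > 166000 nM. The steps a step that the two limits leave unreadable from compound 1 to compound 2, a step that the two limits leave unreadable from compound 1 to compound 3 and a step that the two limits leave unreadable from compound 2 to compound 3 therefore cannot be sized, because of the limit of > 166000 nM in this assay, at which 3 of the 3 values shown sit. Compound 3 thus stands nowhere apart from the other two on the numbers shown: all three sit at the same limit, and no ordering among them can be read.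

Compound 4 `OC[C@H]1O[C@@H](n2cnc3c(NCc4ccc(F)cc4Cl)ncnc32)[C@H](O)[C@@H]1O` differs from compound 3 by 2-chloro-4-fluorophenyl in place of 3-methoxyphenyl on a saturated chain carbon bound to a nitrogen on an aromatic ring. Within the data shown here, none of the measured steps resolves what such an exchange on this position does, since each of them runs from one limit to another, and every change tried so far has left the read-out at the limit. Compound 4 is therefore expected to behave in the same way, with the step of a number no higher from compound 3 to compound 4 (the limit leaves the size open) expected to be none beyond the scatter. Compound 4 is estimated at 166000 nM, within 50000 nM to 500000 nM, most probably reported again only as a limit.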

Compound 4, half-maximal inhibitory concentration: > 166000 nM
Compound 4: a limit, no number; the forecaster's own chance of this, stated with the estimate: 80%; the middle value sits exactly at the limit.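

In this assay compound 4 returns only a limit, > 166000 nM. Its steps from compound 1, compound 2 and compound 3 cannot be read, because all four compounds share one limit: the limit of > 166000 nM in this assay, at which 4 of the 4 values shown sit. The compounds shown leave open whether these exchanges of the benzyl group have any effect on antiproliferative activity, and of what size.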